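A few compounds are considered here, and "the series" means these few. Any claim that something is new, unique, unknown or untested is made for them only; others in the source may bear on it.

Compound 1 `CCCn1nc(-c2cccnc2)c2ccccc2c1=O`: 86%
Compound 2 `C=CCn1nc(-c2cccnc2)c2ccccc2c1=O`: 70%
Compound 3 `O=c1c2ccccc2c(-c2cccnc2)nn1C1CCCC1`: 97%

In an assay on isolated protein (Oryctolagus cuniculus) with Thromboxane-A synthase (Homo sapiens) as the target, tested at 1 uM (a lower number here means less inhibition, a higher number more inhibition at the concentration tested (going by the name of the read-out)), compound 3 stands highest of the three measured compounds, above compound 1 by a number 11 percentage points higher from compound 1 to compound 3 (beyond the scatter) and above compound 2 by a number 27 percentage points higher from compound 2 to compound 3 (beyond the scatter). Compound 4 `O=c1c2ccccc2c(-c2cccnc2)nn1Cc1cccc(Cl)c1` differs from compound 3 by 3-chlorobenzyl in place of cyclopentyl on an aromatic nitrogen. The measured steps all exchange the group on that aromatic nitrogen, and their sizes were modest: a number 16 percentage points lower from compound 1 to compound 2 (beyond the scatter), a number 11 percentage points higher from compound 1 to compound 3 (beyond the scatter) and a number 27 percentage points higher from compound 2 to compound 3 (beyond the scatter). None of them brings in an aromatic ring, so they bear on compound 4 only loosely, and compound 3 leaves little room above it. A small drop or no change beyond the scatter is the expectation. Compound 4 is therefore estimated to give 86% in this assay, with a range from 65% to 99%. The expected step is a number 11 percentage points lower from compound 3 to compound 4 (beyond the scatter).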

Compound 4, a percentage reported as inhibition, at one concentration (the size of the read-out at that concentration, not a potency): 95%
Beside the measured number, compound 4's estimate is 9 percentage points below it; measured number inside the range.
By their numbers in this assay, from the lowest: compound 2; then compounds 1, 4 and 3 (each within the scatter of the next, the first and the last beyond it).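

In this assay, the aromatic ring of 3-chlorobenzyl is accepted on the aromatic nitrogen in place of cyclopentyl, with a number 2 percentage points lower from compound 3 to compound 4 (within the scatter). Against the open chains the picture is split: a number 9 percentage points higher from compound 1 to compound 4 (within the scatter), whereas a number 25 percentage points higher from compound 2 to compound 4 (beyond the scatter). Nothing available explains why this position accepts the aromatic ring.

The compounds shown leave open what the chlorine itself contributes. They also leave open whether a plain benzyl, or a benzyl carrying an amine or a carboxylic acid, would hold this level.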